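Bromo for chloro on the ketone-linked core: solubility notes

This account rests on a few compounds, and the source may have more. Where it says the series, first, only, none or still open, it means among the compounds named here.

Measured so far in a physicochemical assay for solubility; a lower number here means a less soluble compound, a higher number a more soluble compound:
compound 1 `Cc1cc(C)cc(Cc2cc(Br)ccc2OCCn2ccc(=O)[nH]c2=O)c1` — 1200 nM
compound 2 `Cc1cccc(Cc2cc(C)ccc2OCCn2ccc(=O)[nH]c2=O)c1` — 36500 nM
compound 3 `Cc1cc(C)cc(C(=O)c2cc(Cl)ccc2OCCn2ccc(=O)[nH]c2=O)c1` — 3700 nM

Compound 3 stands second highest of the three numbers in this assay with 3700 nM. Compound 1 sits closest at 1200 nM, a lower number beyond the scatter, and compound 2 sits furthest at 36500 nM, a higher number beyond the scatter. No two of these measured compounds differ in one place only, so no single change has an isolated step here.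

Compound 4 `Cc1cc(C)cc(C(=O)c2cc(Br)ccc2OCCn2ccc(=O)[nH]c2=O)c1` is not yet measured. Relative to compound 3 it carries bromo in place of chloro on an aromatic carbon. For the measured compounds named here, the existing numbers give no step for this halogen exchange on its own; compound 1 carries bromo on a differently linked core, which does not separate the exchange from the linker. The step is expected to be small and, if anything, toward a lower number, likely within the scatter: a 1.4-fold lower number from compound 3 to compound 4 (0.15 log units; within the scatter). Compound 4 is therefore estimated at 2600 nM, with a range of 1000 nM to 6500 nM.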

Compound 4, solubility: 1800 nM
Compound 4: the middle estimate sits 1.4-fold (0.16 log units) above what was measured; the measured number falls inside the stated range.
By their numbers in this assay, from the lowest: compounds 1 and 4 (each within the scatter of the next); then compound 3; then compound 2.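

In this assay, the exchange of chloro for bromo on this aromatic carbon now has an isolated step on the ketone-linked core: a 2.1-fold lower number from compound 3 to compound 4 (0.31 log units; beyond the scatter), modest but beyond the scatter. With bromo on both, compound 1 at 1200 nM and compound 4 at 1800 nM lie within the scatter of each other, though they differ in the link between the two aromatic rings. Nothing available bears on the reason for the halogen step.

One step on one core leaves open whether the same exchange would give a similar change with the link of compound 1. Also open, on these data alone, is how an amine or a carboxylic acid on this aromatic carbon would stand against chloro and bromo.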